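A few compounds are considered here, and "the series" means these few. Any claim that something is new, unique, unknown or untested is made for them only; others in the source may bear on it.

Compound 1 `CN(C)CCC(=O)c1cc2ccc(O)cc2oc1=O`: 110000 nM
Compound 2 `Cc1cc(O)cc2oc(=O)c(C(=O)CCN(C)C)cc12`: > 200000 nM

Compound 1 `CN(C)CCC(=O)c1cc2ccc(O)cc2oc1=O` gives 110000 nM in an assay on cells for inhibition of Amine oxidase [flavin-containing] A (Homo sapiens), read by fluorescence, spectrophotometry and Amplex Red, with stated times of 60 min and 30 min; a higher number here means a weaker inhibitor, a lower number a stronger inhibitor. Compound 2 `Cc1cc(O)cc2oc(=O)c(C(=O)CCN(C)C)cc12` reaches only the limit of the assay in this assay, > 200000 nM, so no number is known for it; the limit of > 200000 nM in this assay, at which 1 of the 2 values shown sits, is where it stands. Among the compounds with values here, the single measured step, an at least 1.8-fold higher number from compound 1 to compound 2 (0.25 log units; that floor lies within the scatter), is a change of a ring substituent and says nothing about the amine at the end of the chain. Compound 3 `Cc1cc(O)cc2oc(=O)c(C(=O)CCN3CCCC3)cc12` differs from compound 2 by pyrrolidin-1-yl in place of dimethylamino on a saturated chain carbon, two bonds along the chain from a carbonyl carbon. Within the data shown here, no measured step bears on this change, so the account has nothing to set against it. Compound 3 is expected to sit where compound 2 sits. The step that the limit leaves unreadable from compound 2 to compound 3 is therefore expected to be none beyond the scatter. Compound 3 is thus estimated at 250000 nM in this assay, within 100000 nM to 800000 nM, and most likely the assay will again report only a limit and no number for it.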

Compound 3, half-maximal inhibitory concentration: 173000 nM
Estimate against measurement, compound 3: 1.4-fold (0.16 log units) above, within the range that was stated.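

With pyrrolidin-1-yl in place of dimethylamino on a saturated chain carbon, two bonds along the chain from a carbonyl carbon, compound 3 gives a real number in this assay, 173000 nM, so this change at the end of the chain can at last be placed on the scale of the assay. For compound 2 the assay gives only a limit, > 200000 nM. The change therefore reads as an at least 1.1-fold lower number from compound 2 to compound 3 (0.06 log units; that floor lies within the scatter), and no shift beyond the scatter can be claimed for it, because the starting point of this step is a limit and not a number: the limit of > 200000 nM in this assay, at which 1 of the 3 values shown sits.

As far as these compounds go, it remains open how a piperidin-1-yl or a morpholin-4-yl group at this place would read, and how a longer chain between the carbonyl and the amine would read. Also open, from the compounds shown here alone, is how pyrrolidin-1-yl reads on the core of compound 1, where the dimethylamino side of the comparison stands as a number and not as a limit.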